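Pyrazin-2-yl in Place of 1,3-Oxazol-5-yl

The compounds below may be only part of what the source reports. "The series", "measured", "known", "first", "only" and "open" are said of these compounds alone.

In a functional assay on CHO-K1 cells for antagonist activity at adenosine receptor A1 (Homo sapiens), read by a beta-galactosidase reporter and cAMP accumulation, with stated times of 15 min and 6 h (a lower number here means a stronger inhibitor, a higher number a weaker inhibitor), compound 1 `Nc1nc(-c2cnco2)nc2sc(Cc3ccccc3)cc12` stands at 106 nM, and compound 2 `COc1ccccc1Cc1cc2c(N)nc(-c3nc(C)cs3)nc2s1` at 186 nM lies within the scatter of it. Compound 3 `C=C(c1ccccc1)c1cc2c(N)nc(-c3cccc(C#N)c3)nc2s1` reaches only > 1000 nM in this assay, which is a limit and not a number (the limit of > 1000 nM in this assay, at which 1 of the 3 values shown sits). Compound 4 `Nc1nc(-c2cnccn2)nc2sc(Cc3ccccc3)cc12` has not yet been measured in this assay. It differs from compound 1 by pyrazin-2-yl in place of 1,3-oxazol-5-yl on an aromatic carbon. Going by the values given here, no measured pair bears on this change, so no size of step can be read from the data; the expectation is a step no larger than the scatter, in no particular direction. The expected step is a 1.1-fold higher number from compound 1 to compound 4 (0.05 log units; within the scatter). Compound 4 is estimated at 120 nM in this assay, with a range from 40 nM to 400 nM.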

Compound 4, inhibition constant: 91 nM
Compound 4: the middle estimate sits 1.3-fold (0.12 log units) above what was measured; measured number inside the range.
By their numbers in this assay, from the lowest: compounds 4, 1 and 2 (each within the scatter of the next, the first and the last beyond it). At a limit, above all of these: compound 3.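

In this assay, going by these compounds alone, the first measured pair at this position gives a 1.2-fold lower number from compound 1 to compound 4 (0.07 log units; within the scatter), so the change from a five-membered to a six-membered aromatic ring, each with 2 hetero atoms, leaves the read-out within the scatter. Between two ring nitrogen atoms of the core, on this aromatic carbon, the two rings cannot be told apart in this pair. No measured evidence here speaks to why the two rings read alike.

From the compounds shown here alone, what an amine or a carboxylic acid on the pyrazin-2-yl ring would do remains open. So does the effect of a saturated ring such as morpholine in the same place.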